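A few compounds are considered here, and "the series" means these few. Any claim that something is new, unique, unknown or untested is made for them only; others in the source may bear on it.

Measured so far in a functional assay on HL-60 cells (Homo sapiens) for antiproliferative activity, read by XTT assay, with a stated time of 72 h; on this read-out higher numbers stand for weaker inhibition and lower numbers for stronger inhibition:
compound 1 `COc1ncnc2c1c(-c1cccs1)cn2[C@@H]1O[C@H](CO)[C@@H](O)[C@H]1O` — 80 nM
compound 2 `CN(C)c1ncnc2c1c(-c1cccs1)cn2[C@@H]1O[C@H](CO)[C@@H](O)[C@H]1O` — 11800 nM

Going by the values given here, compound 1 holds the lower of the two numbers; the only measured step, a 150-fold higher number from compound 1 to compound 2 (2.17 log units; beyond the scatter), concerns the dimethylamino in place of methoxy on an aromatic carbon and says nothing about the ring that sits on the five-membered ring of the core. Compound 3 `COc1ncnc2c1c(-c1ccco1)cn2[C@@H]1O[C@H](CO)[C@@H](O)[C@H]1O` differs from compound 1 as follows: furan-2-yl in place of thiophen-2-yl on an aromatic carbon. Among the compounds with values here, no measured step bears on this exchange, so the expected size of the step in this assay is none beyond the scatter. Compound 3 is therefore estimated at 120 nM (range 35 nM to 450 nM), that is a 1.5-fold higher number from compound 1 to compound 3 (0.18 log units; within the scatter) expected.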

Compound 3, half-maximal inhibitory concentration: 100 nM
Compound 3: the middle estimate sits 1.2-fold (0.08 log units) above what was measured; the measured number falls inside the stated range.
By their numbers in this assay, from the lowest: compounds 1 and 3 (each within the scatter of the next); then compound 2.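

In this assay, furan-2-yl in place of thiophen-2-yl gives a 1.3-fold higher number from compound 1 to compound 3 (0.10 log units; within the scatter), so the two groups cannot be told apart on this read-out. Going by these compounds alone, this is the only reading so far on the group at this aromatic carbon of the five-membered ring, and it shows that oxygen can stand for sulfur in that ring without a step beyond the scatter. Nothing available accounts for this result. Going by these compounds, whether a phenyl ring, a short alkyl chain or an amine would be accepted on this carbon remains open. Also open, on these data alone, is how furan-2-yl behaves with dimethylamino in place of methoxy.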